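The compounds below may be only part of what the source reports. "The series", "measured", "known", "first", "only" and "open" are said of these compounds alone.

For the measured compounds named here, compound 2, `CN(C)c1ccc(C2CC(c3ccc(-n4cncn4)cc3)=NN2C(=O)c2cc(Cl)cc(Cl)c2)cc1`, is one of two compounds measured in a functional assay on MDA-MB-231 cells (Homo sapiens) for inhibition, read by sulforhodamine B assay, tested at 10 uM; on this read-out higher numbers stand for more inhibition at the one concentration tested (going by the name of the read-out) and lower numbers for less inhibition. In this assay compound 2 gives 9.4%. The other is compound 1, `CN(C)c1ccc(C2CC(c3ccc(-n4cncn4)cc3)=NN2)cc1`, which carries hydrogen on the amine nitrogen in the ring; in this assay compound 1 gives 7%. The two values sit together: a number 2.4 percentage points higher from compound 1 to compound 2 (within the scatter), so neither can be said to differ from the other.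

Compound 3, `Cc1ccc(S(=O)(=O)N2N=C(c3ccc(-n4cncn4)cc3)CC2c2ccc(N(C)C)cc2)cc1`, has not yet been measured. It differs from compound 2 in one place: (4-methylphenyl)sulfonyl in place of (3,5-dichlorophenyl)carbonyl on an amine nitrogen in a ring. Going by the values given here, the one measured step that bears on this position, from compound 1 to compound 2, shows that adding a group on the amine nitrogen in the ring moved the read-out by an amount within the scatter. On that basis the step of a number 0.6 percentage points higher from compound 2 to compound 3 (within the scatter) is expected to stay within the scatter as well, in no particular direction. Compound 3 is therefore estimated to give 10% in this assay, with a range from 0% to 25%.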

Compound 3, a percentage reported as inhibition, at one concentration (the size of the read-out at that concentration, not a potency): 20.7%
For compound 3 the middle estimate is 10.7 percentage points below the measured one; measured number inside the range.
By their numbers in this assay, from the lowest: compounds 1 and 2 (each within the scatter of the next); then compound 3.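

In this assay, a group on the amine nitrogen in the ring can change the read-out beyond the scatter: replacing hydrogen with (4-methylphenyl)sulfonyl gives a number 13.7 percentage points higher from compound 1 to compound 3 (beyond the scatter) on this measure. The choice of group also counts, as exchanging (3,5-dichlorophenyl)carbonyl for (4-methylphenyl)sulfonyl, both of 10 heavy atoms, gives a number 11.3 percentage points higher from compound 2 to compound 3 (beyond the scatter) in the same read-out. Nothing available explains why this exchange shifts the number.

This exchange alters the carbonyl link and the ring substituents together, and the compounds shown cannot say which of the two carries the step. A (4-methylphenyl)carbonyl group or a (3,5-dichlorophenyl)sulfonyl group would pull these apart, while a methylsulfonyl group would test whether the aromatic ring of the sulfonyl group matters at all.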